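This account rests on a few compounds, and the source may have more. Where it says the series, first, only, none or still open, it means among the compounds named here.

Going by the values given here, compound 1 `O=C(Nc1ccc(Oc2ccnc3[nH]ccc23)cc1)c1cc2cccnc2n(-c2ccc(F)cc2)c1=O` is the one member of this small set with a number behind it. In a functional assay on U-87MG ATCC cells for antiproliferative activity against U-87 MG (Homo sapiens), read by MTT assay, with a stated time of 72 h (on this read-out lower numbers stand for stronger inhibition and higher numbers for weaker inhibition), compound 1 gives 1360 nM, and since this is the only result reported, there is nothing to rank it against: it neither leads nor trails anything. Compound 2 `O=C(Nc1ccc(Oc2ccnc3[nH]ccc23)cc1)c1cc2cccnc2n(-c2ccc(Br)cc2)c1=O` carries a bromo in place of the fluoro of compound 1. In this assay compound 2 is entered as "not determined" (no result reported), so no result is reported for it and nothing can be said about its strength.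

Compound 3 `COc1ccc(-n2c(=O)c(C(=O)Nc3ccc(Oc4ccnc5[nH]ccc45)cc3)cc3cccnc32)cc1` is the compound to be measured next. It differs from compound 1 in one place: methoxy in place of fluoro on an aromatic carbon, para to a large group. Among the compounds with values here, no measured pair shows the effect of such a swap here, so the expected size of the step rests on compound 1 alone. The step from compound 1 to compound 3 is expected to be small, at most a modest weakening that may not rise above the scatter, a 1.3-fold higher number from compound 1 to compound 3 (0.12 log units; within the scatter). Compound 3 is therefore estimated at 1800 nM, with a range from 600 nM to 5400 nM.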

Compound 3, half-maximal inhibitory concentration: 2350 nM
Beside the measured number, compound 3's estimate is 1.3-fold (0.12 log units) below it; the measured number falls inside the stated range.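

Going by these compounds alone, this is the first measured step at this position: in this assay, going from 4-fluorophenyl to 4-methoxyphenyl gives a 1.7-fold higher number from compound 1 to compound 3 (0.24 log units; within the scatter) and so leaves the two compounds indistinguishable on this read-out. The position therefore accepts a methoxy, with two heavy atoms and one hydrogen-bond acceptor, in place of a fluoro, with one heavy atom and no acceptor, without a difference that rises above the ordinary spread of repeated measurements. Nothing in the data gives a reason for this, so it remains an observation from a single pair of compounds.

Any step involving compound 2 cannot be read, since its bromo comes with no number, and one pair cannot show whether other groups at this position would behave the same way. The compounds shown leave open how an amine, a carboxylic acid or a longer chain such as ethoxy on the same aromatic carbon would compare with the fluoro of compound 1.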